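Series notes: estimate for compound 4

A few compounds are considered here, and "the series" means these few. Any claim that something is new, unique, unknown or untested is made for them only; others in the source may bear on it.

Measured so far in a functional assay on BaF3 cells (Mus musculus) for inhibition, read by CCK-8 assay, with a stated time of 72 h; a higher number here means a weaker inhibitor of growth, a lower number a stronger inhibitor of growth:
compound 1 `COc1ccc(CNc2cc(Oc3ccc(NC(=O)Nc4ccc(C)c(C(F)(F)F)c4)cc3)ncn2)cc1` gives 1000 nM
compound 2 `C=CC(=O)Nc1cc(Oc2ccc(NC(=O)Nc3ccc(C)c(C(F)(F)F)c3)cc2)ncn1` gives 1940 nM
compound 3 `Cc1ccc(NC(=O)Nc2ccc(Oc3cc(N4CCNC[C@@H]4C)ncn3)cc2)cc1C(F)(F)F` gives 8120 nM

Compound 3 shows the highest number of the three in this assay, with an 8.1-fold higher number from compound 1 to compound 3 (0.91 log units; beyond the scatter) and a 4.2-fold higher number from compound 2 to compound 3 (0.62 log units; beyond the scatter) both beyond the scatter. Compound 4 `COCCNc1cc(Oc2ccc(NC(=O)Nc3ccc(C)c(C(F)(F)F)c3)cc2)ncn1` differs from compound 3 in one place: (2-methoxyethyl)amino in place of 2-methylpiperazin-1-yl on an aromatic carbon. The two steps that bear on this each put the 2-methylpiperazin-1-yl group in place of a nitrogen-linked group and raised the number modestly; reversing that direction points toward a lower number for compound 4 in this assay. Among the compounds with values here, no measured step compares two nitrogen-linked groups with each other, so the size rests on those two steps alone. Compound 4 is therefore expected to show a 5.4-fold lower number from compound 3 to compound 4 (0.73 log units; beyond the scatter). The estimate for compound 4 is 1500 nM, within 600 nM to 4000 nM.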

Compound 4, concentration for 50% growth inhibition: 7950 nM
Beside the measured number, compound 4's estimate is 5.3-fold (0.72 log units) below it; the measured number lies above the stated range.
By their numbers in this assay, from the lowest: compounds 1 and 2 (each within the scatter of the next); then compounds 4 and 3 (each within the scatter of the next).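

In this assay, a 1.0-fold lower number from compound 3 to compound 4 (0.01 log units; within the scatter) sets (2-methoxyethyl)amino level with 2-methylpiperazin-1-yl on this aromatic carbon, so the open chain and the ring are not told apart here. The same chain gives a 4.1-fold higher number from compound 2 to compound 4 (0.61 log units; beyond the scatter) against the vinylcarbonyl group and an 8.0-fold higher number from compound 1 to compound 4 (0.90 log units; beyond the scatter) against the 4-methoxybenzyl group, so a linking nitrogen alone does not give the lower numbers of compound 1 and compound 2. Nothing at hand explains these steps.

Open, from the compounds shown here alone, is whether the ring of the 4-methoxybenzyl group matters, which an unsubstituted benzylamine would test. Also open, going by these compounds, is whether a saturated amide such as propanamide matches the vinylcarbonyl group.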